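This account rests on a few compounds, and the source may have more. Where it says the series, first, only, none or still open, it means among the compounds named here.

Measured so far:
Compound 1 `CC(=O)NCc1cccc(Cn2nc(NS(=O)(=O)c3ccc(Cl)s3)c3ccccc32)c1`: 5.93
Compound 2 `CC(=O)NCc1cccc(Cn2nc(NS(=O)(=O)c3ccc(Cl)s3)c3c(O)cccc32)c1`: 6.12

For the measured compounds named here, compound 1 gives the lower of the two numbers in a physicochemical assay for acid dissociation; its only neighbour is compound 2, and the step of a number 0.19 log units higher from compound 1 to compound 2 (within the scatter) is too small to count as a real change. That step is the only one measured at the aromatic carbon in question, so it is the one that bears on the new compound.

Compound 3 `CC(=O)NCc1cccc(Cn2nc(NS(=O)(=O)c3ccc(Cl)s3)c3c(C(F)F)cccc32)c1` differs from compound 1 by difluoromethyl in place of hydrogen on an aromatic carbon. Going by the values given here, the one change already made at this carbon moved the acid dissociation constant hardly at all, and no other measured step tells anything about a difluoromethyl group. The step of a number 0.18 log units lower from compound 1 to compound 3 (within the scatter) is therefore expected to be small, at most a modest shift, with little reason to look for anything beyond the scatter. Compound 3 is estimated to give 5.75, within a range of 5.35 to 6.15.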

Compound 3, acid dissociation constant: 5.6
Beside the measured number, compound 3's estimate is 0.15 log units above it, within the range that was stated.
By their numbers in this assay, from the lowest: compound 3; then compounds 1 and 2 (each within the scatter of the next).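

At this aromatic carbon, this assay now shows a real change: difluoromethyl in place of hydrogen gives a number 0.33 log units lower from compound 1 to compound 3 (beyond the scatter), whereas the earlier hydroxy step stayed within the scatter. Exchanging one group for the other at the same carbon gives a number 0.52 log units lower from compound 2 to compound 3 (beyond the scatter), so the choice of group at this place can shift the number, though only modestly in these compounds. No supporting data bear on why the number moves in this direction.

Going by these compounds, whether an amine, a methoxy group or a carboxylic acid at this carbon would shift the number further, or the opposite way, remains open. With only hydrogen, hydroxy and difluoromethyl to compare here, no trend across groups can be drawn, and whether difluoromethyl would have a similar effect on another carbon of the shared core is also unknown.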